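Adding chloro to the aryl group of compound 2

A few compounds are considered here, and "the series" means these few. Any claim that something is new, unique, unknown or untested is made for them only; others in the source may bear on it.

Measured so far in a functional assay on OVCAR-3 cells (Homo sapiens) for antiproliferative activity, read by spectrophotometry, with a stated time of 2 days; on this read-out higher numbers stand for weaker inhibition of growth and lower numbers for stronger inhibition of growth:
- Compound 1 `Cc1cc(C)cc(Nc2ncc(C(F)(F)F)c(N3Cc4cccc(N(C)S(C)(=O)=O)c4C3)n2)c1` gives > 30000 nM as a limit
- Compound 2 `CN(c1cccc2c1CN(c1nc(Nc3cccc(C(F)(F)F)c3)ncc1C(F)(F)F)C2)S(C)(=O)=O` gives > 30000 nM as a limit

Compound 2 stands only at a limit, > 30000 nM, so no number is known for it. The whole picture so far is the limit of > 30000 nM in this assay, at which 2 of the 2 values shown sit. Compound 3 `CN(c1cccc2c1CN(c1nc(Nc3cc(Cl)cc(C(F)(F)F)c3)ncc1C(F)(F)F)C2)S(C)(=O)=O` carries chloro in place of hydrogen on an aromatic carbon, meta to a trifluoromethyl group, which turns 3-(trifluoromethyl)phenyl into 3-chloro-5-(trifluoromethyl)phenyl (chloro in place of hydrogen on an aromatic carbon). Within the data shown here, the only measured step bearing on this is a step that the two limits leave unreadable from compound 1 to compound 2, which puts 3-(trifluoromethyl)phenyl in place of 3,5-dimethylphenyl and offers no size to carry over. In this assay no change beyond the usual scatter is therefore expected, and no direction can be given. The expected step is a number no higher from compound 2 to compound 3 (the limit leaves the size open). Compound 3 is estimated at 30000 nM, with an expected range of 10000 nM to 40000 nM, and another limit is the likelier report.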

Compound 3, concentration for 50% growth inhibition: 21500 nM
Compound 3: the middle estimate sits 1.4-fold (0.14 log units) above what was measured; the measured number falls inside the stated range.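

In this assay, among these compounds, compound 3 gives 21500 nM, the only actual number among the three compounds. Compound 1 and compound 2 remain at a limit: the limit of > 30000 nM in this assay, at which 2 of the 3 values shown sit. Chloro in place of hydrogen on an aromatic carbon, meta to a trifluoromethyl group, gives an at least 1.3-fold lower number from compound 2 to compound 3 (0.14 log units; that floor lies within the scatter), and the full exchange of the aryl group gives an at least 1.3-fold lower number from compound 1 to compound 3 (0.14 log units; that floor lies within the scatter). Both are floors rather than sizes, so this position tolerates chloro and yields a readable value, but no real gain can be claimed, and the step between the two limits cannot be read.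

On these data alone, what remains open is whether fluoro, bromo, methoxy or nitrile at this position would also give a number. As far as these compounds go, it is also open whether chloro would do so without the trifluoromethyl group on the same ring.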